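A few compounds are considered here, and "the series" means these few. Any claim that something is new, unique, unknown or untested is made for them only; others in the source may bear on it.

This piece follows what happens in an ADME assay on HEK293 cells (Homo sapiens) for cytotoxicity, read by resazurin assay, with a stated time of 48 h (a lower number here means that less compound is tolerated, a higher number that more compound is tolerated), when the group on the sulfonyl sulfur is exchanged. Compound 1 `COc1ccc(S(=O)(=O)Nc2ccc(-c3nc4ccccc4o3)cc2)cc1` reaches only a limit of the assay, > 100000 nM, not a number. Compound 2 `O=S(=O)(Nc1ccc(-c2nc3ccccc3o2)cc1)c1ccc(Cl)s1` likewise stops at a limit, > 100000 nM. The third measured compound, compound 3 `C=Cc1ccc(S(=O)(=O)Nc2ccc3oc(-c4ccccc4)nc3c2)cc1`, does give a number in this assay, 53000 nM. For the measured compounds named here, the single step between measured compounds that differ in one place, a step that the two limits leave unreadable from compound 1 to compound 2, cannot be read in size: both of its ends sit at the limit of > 100000 nM in this assay, at which 2 of the 3 values shown sit. Compound 2 therefore stands at the edge of the numbers shown, together with compound 1, while compound 3 alone gives a readable value in this assay.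

Compound 4 `CS(=O)(=O)Nc1ccc(-c2nc3ccccc3o2)cc1` differs from compound 2 by methyl in place of 5-chlorothiophen-2-yl on a sulfonyl sulfur. No measured step covers this exchange; the only comparison at the same place, a step that the two limits leave unreadable from compound 1 to compound 2, was unreadable, so nothing among the shown numbers argues for a change beyond the scatter. Compound 4 is accordingly expected to sit at the limit again, with an estimated step of a number no higher from compound 2 to compound 4 (the limit leaves the size open). The expected value for compound 4 in this assay is 100000 nM, with a range from 40000 nM to 300000 nM.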

Compound 4, half-maximal cytotoxic concentration: > 100000 nM
Compound 4: a limit, no number (the forecaster's own chance of this, stated with the estimate: 70%); the middle value lies on the limit itself.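

Compound 4 also gives only a limit of the assay, so the steps linking compound 1, compound 2 and compound 4 cannot be read in size, all three sitting at the same edge: the limit of > 100000 nM in this assay, at which 3 of the 4 values shown sit.

The compounds shown leave open whether exchanging the group on the sulfonyl sulfur changes the tolerated concentration in this assay at all.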